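A pyridine ring in place of a phenyl on the amide

The compounds below may be only part of what the source reports. "The series", "measured", "known", "first", "only" and "open" are said of these compounds alone.

Measured so far:
compound 1, `Cc1cc(C(=O)O)nn1Cc1cc(Br)ccc1OCc1ccccc1`: 6.31 nM in an assay on CHO-K1 cells for displacement of a labelled ligand from prostaglandin E2 receptor EP1 subtype (Homo sapiens); a lower number here means a stronger inhibitor, a higher number a weaker inhibitor
compound 2, `Cc1cc(C(=O)Nc2ccccc2)nn1Cc1cc(Cl)ccc1OCc1ccccc1`: 39.8 nM in this assay

Compound 2 gives the higher of the two numbers; compound 1 gives a lower one, and the gap between them lies beyond the usual scatter. The two differ in more than one place, so the gap cannot be tied to a single change. Compound 3, `Cc1cc(C(=O)Nc2ccccn2)nn1Cc1cc(Cl)ccc1OCc1ccccc1`, is not yet measured. It differs from compound 2 in one place only: pyridin-2-yl in place of phenyl on an amide-type nitrogen. For the measured compounds named here, no measured pair shows this change, so there is no direct guide to its effect. The expectation is a step of no more than the scatter, in either direction. For compound 3 the estimated value in this assay is 40 nM, within a range from 10 nM to 160 nM, which means an expected step of a 1.0-fold higher number from compound 2 to compound 3 (0.00 log units; within the scatter).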

Compound 3, half-maximal inhibitory concentration: 126 nM
The estimate for compound 3 lay 3.2-fold (0.50 log units) below the measured number; measured number inside the range.
By their numbers in this assay, from the lowest: compound 1; then compound 2; then compound 3.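

Swapping phenyl for pyridin-2-yl on the amide-type nitrogen gives a 3.2-fold higher number from compound 2 to compound 3 (0.50 log units; beyond the scatter) in this assay, and this is the first gap in the series that can be tied to a single change. It shows that this position responds to a small edit: the two rings have the same number of heavy atoms, and the entering ring differs by one ring nitrogen, which adds one hydrogen-bond acceptor. No measurement here explains why the number rises.

The compounds shown leave open whether the ring nitrogen itself drives this step, and how other groups on the same amide nitrogen would behave. A pyrimidine ring, with a second ring nitrogen, or a saturated cyclohexyl group in the same place would test this further.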